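Aminomethyl in place of trifluoromethoxy on the shared core

The source may report more compounds than this note shows. Statements on the series, on what has been measured and on what is new or still open speak of the compounds shown alone.

The series is followed in an assay on isolated protein for inhibition of GMP reductase 2 (Homo sapiens), read by spectrophotometry; on this read-out lower numbers stand for stronger inhibition and higher numbers for weaker inhibition. Compound 1 `C[C@H](Oc1cccc(Cl)c1Cl)C(=O)Nc1ccc2oc(-c3ccc(OC(F)(F)F)cc3)nc2c1` carries a trifluoromethoxy on the outer phenyl. In this assay compound 1 gives > 5000 nM, which is a limit of the assay and not a number. Compound 2 `COc1ccc(-c2nc3cc(NC(=S)[C@H](C)Oc4cccc(Cl)c4Cl)ccc3o2)cc1`, the thioamide with a methoxy on the outer phenyl, also reaches only a limit. In this assay compound 2 gives > 5000 nM. Compound 1 thus stands at the limit of > 5000 nM in this assay, at which 2 of the 2 values shown sit, so no ranking against compound 2 is possible. Within the data shown here, no step between measured compounds that differ in one place is available.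

Compound 3 `C[C@H](Oc1cccc(Cl)c1Cl)C(=O)Nc1ccc2oc(-c3ccc(CN)cc3)nc2c1` is not yet measured in this assay. It differs from compound 1 as aminomethyl in place of trifluoromethoxy on an aromatic carbon. With only limits to lean on, the step is expected to be an at least 1.2-fold lower number from compound 1 to compound 3 (0.09 log units; that floor lies within the scatter), and its direction cannot be fixed beyond the scatter. Compound 3 is estimated at 4000 nM, within 800 nM to 20000 nM.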

Compound 3, inhibition constant: > 5000 nM
Compound 3: no number, only a limit; the forecaster's own chance of this, stated with the estimate: 55%; middle value at least 1.2-fold (0.09 log units) from the limit.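

In this assay, among these compounds, compound 3 gives > 5000 nM, a limit of the assay and not a number, so no step between compound 1 and compound 3 can be read. The compounds shown leave open which change on the shared core, if any, would give a measurable number: the limit of > 5000 nM in this assay, at which 3 of the 3 values shown sit.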